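A few compounds are considered here, and "the series" means these few. Any claim that something is new, unique, unknown or untested is made for them only; others in the source may bear on it.

Compound 1 `C/C=C/C(=O)Nc1cc2c(N3CCCc4ccccc43)ncnc2cc1OC` gives, in a functional assay on PC-3 cells (Homo sapiens) for antiproliferative activity, read by MTT assay, with a stated time of 72 h (on this read-out higher numbers stand for weaker inhibition and lower numbers for stronger inhibition), a value of 7520 nM, the lowest of the two numbers seen so far, though compound 2 `C/C=C/C(=O)Nc1cc2c(N3CCCc4ccccc43)ncnc2cc1O[C@@H]1CCOC1` with 9350 nM lies within the scatter of it, as the step of a 1.2-fold higher number from compound 1 to compound 2 (0.09 log units; within the scatter) shows. Compound 3 `CCN(CC)C/C=C/C(=O)Nc1cc2c(N3CCCc4ccccc43)ncnc2cc1OC` differs from compound 1 by diethylamino in place of hydrogen on a saturated chain carbon bound to a double-bonded chain carbon. Among the compounds with values here, no measured step touches this position, so nothing in the data constrains the direction beyond an expectation of a modest shift. Compound 3 is therefore expected to come out near 3000 nM, between 800 nM and 12000 nM, an estimated step of a 2.5-fold lower number from compound 1 to compound 3 (0.40 log units; beyond the scatter).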

Compound 3, half-maximal inhibitory concentration: 6890 nM
Beside the measured number, compound 3's estimate is 2.3-fold (0.36 log units) below it; the measured number falls inside the stated range.
By their numbers in this assay, from the lowest: compounds 3, 1 and 2 (each within the scatter of the next).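

Placing diethylamino on the saturated chain carbon bound to a double-bonded chain carbon gives no readable change in this assay (a 1.1-fold lower number from compound 1 to compound 3 (0.04 log units; within the scatter)). Compound 1 and compound 2 said nothing about this position; compound 3 shows that it accepts this group of 5 heavy atoms with the number staying within the scatter. Nothing measured here offers an explanation for this result. The compounds shown leave open whether a smaller amine such as dimethylamino, or a ring amine such as piperidine, would read the same at this place. They also leave open whether diethylamino would behave alike with oxolan-3-yl on the oxygen.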